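Butyl in place of phenyl on compound 1

The source may hold more compounds than are shown below. What is called first, only, known or untested is meant among the compounds shown, and "the series" means these compounds.

- compound 1 `O=C(NCc1cc(Cl)ccc1-n1cnnn1)[C@@H]1CC=NN1C(=O)[C@H](O)c1ccccc1` gives 7 10^-6 cm/s
- compound 2 `CC1(C[C@@H](O)C(=O)N2C[C@H]3C[C@H]3[C@H]2C(=O)NCc2cc(Cl)ccc2-n2cnnn2)CC1` gives 2.2 10^-6 cm/s

In an ADME assay on Caco-2 cells (Homo sapiens) for permeability, read by LC-MS, in the apical to basolateral direction, with a stated time of 60 min, at pH 6.5 (a higher number here means that the compound crosses the layer faster, a lower number that the compound crosses the layer more slowly), compound 1 stands highest of the two numbers, with 7 10^-6 cm/s, and the gap down to compound 2 lies beyond the scatter. Compound 3 `CCCC[C@@H](O)C(=O)N1N=CC[C@H]1C(=O)NCc1cc(Cl)ccc1-n1cnnn1` follows from compound 1 by one change, butyl in place of phenyl on a saturated chain carbon bound to a carbonyl carbon and an oxygen on a saturated carbon. Within the data shown here, no measured pair differs in one place, so the data offer no direct guide. In this assay no step beyond the scatter is expected, and the estimated step is a 1.2-fold lower number from compound 1 to compound 3 (0.07 log units; within the scatter). The estimate for compound 3 is 6 10^-6 cm/s, with an expected range from 2.5 10^-6 cm/s to 14 10^-6 cm/s.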

Compound 3, apparent permeability in the Caco-2 assay: 9.8 10^-6 cm/s
Beside the measured number, compound 3's estimate is 1.6-fold (0.21 log units) below it, and the stated range covers the measured number.
By their numbers in the Caco-2 assay, from the lowest: compound 2; then compounds 1 and 3 (each within the scatter of the next).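

In the Caco-2 assay, compound 1 gives 7 10^-6 cm/s and compound 3 gives 9.8 10^-6 cm/s and butyl in place of phenyl on this saturated chain carbon gives a 1.4-fold higher number from compound 1 to compound 3 (0.15 log units; within the scatter), so at this position an open chain can stand in for the aromatic ring without a step beyond the scatter. In a physicochemical assay for solubility, measured as kinetic solubility, at pH 6.8 (a lower number here means a less soluble compound, a higher number a more soluble compound), compound 1 gives 98000 nM and compound 3 gives 59000 nM and the same change gives a 1.7-fold lower number from compound 1 to compound 3 (0.22 log units; within the scatter) and the same holds there. No measurement at hand offers a cause for either step.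

On these data alone, whether a longer chain or an amine on this saturated chain carbon would also stay within the scatter of compound 1 in both assays remains open.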